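A few compounds are considered here, and "the series" means these few. Any claim that something is new, unique, unknown or untested is made for them only; others in the source may bear on it.

Compound 1 `C#CCN(C)CCCCOc1ccc2c(c1)CCC2=O` gives 7.93% in an ADME assay on BTI cells for inhibition of Amine oxidase [flavin-containing] A (Homo sapiens), read by fluorescence and Amplex Red, with a stated time of 15 min, tested at 100 uM; a lower number here means less inhibition, a higher number more inhibition at the concentration tested (going by the name of the read-out). Compound 2 `C#CCN(C)CCCCCCOc1ccc2c(c1)CCC2=O` gives 4.42% in this assay. Compound 3 `C#CCN(C)CCCCCCOc1ccc2c(c1)OCCC2=O` gives 34.1% in this assay.

Compound 2 differs from compound 1 by one change, (2-(methyl(propargyl)amino)ethyl in place of methyl(propargyl)amino on a saturated chain carbon, four bonds along the chain from an oxygen on an aromatic ring), and the step is a number 3.5 percentage points lower from compound 1 to compound 2 (within the scatter). How the core of compound 3 differs from that of compound 1 is not broken down here; compound 3 gives the highest number of the three, beyond the scatter to both others. Compound 4 `C#CCN(C)CCCCCCCCOc1ccc2c(c1)OCCC2=O` carries the same kind of change on the core of compound 3: 2-(methyl(propargyl)amino)ethyl in place of methyl(propargyl)amino on a saturated chain carbon, six bonds along the chain from an oxygen on an aromatic ring. The place is not identical, six bonds along the chain from an oxygen on an aromatic ring rather than four. For compound 4 the expected step is a number 4.1 percentage points lower from compound 3 to compound 4 (within the scatter), resting on the earlier step of a number 3.5 percentage points lower from compound 1 to compound 2 (within the scatter), which lay within the scatter. Compound 4 is therefore estimated at 30%, between 14% and 46%.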

Compound 4, a percentage reported as inhibition, at one concentration (the size of the read-out at that concentration, not a potency): 28.7%
Estimate against measurement, compound 4: 1.3 percentage points above; measured number inside the range.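

In this assay, putting 2-(methyl(propargyl)amino)ethyl in place of methyl(propargyl)amino on the core of compound 3 gives a number 5.4 percentage points lower from compound 3 to compound 4 (within the scatter). Set beside the earlier step, the same change looks alike on the two cores: the same change on two cores in this assay, a number 3.5 percentage points lower (within the scatter) from compound 1 to compound 2 and a number 5.4 percentage points lower (within the scatter) from compound 3 to compound 4, 1.9 percentage points apart, within the scatter of two such steps This shows only that the change leaves no clear mark on the number on either core, so there is no real effect here to carry across, and two cores at a single concentration say nothing about potency or about other cores.

The compounds shown leave open whether a shorter chain, or a simple amine such as dimethylamino in place of methyl(propargyl)amino, would move the number on either core.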